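Cyanophenyl isomers: the step to compound 4

This account rests on a few compounds, and the source may have more. Where it says the series, first, only, none or still open, it means among the compounds named here.

In an ADME assay on MT4 cells (Homo sapiens) for cytotoxicity, read by MTT assay, with a stated time of 5 days (on this read-out lower numbers stand for higher toxicity in this test and higher numbers for lower toxicity in this test), compound 1 `COc1ccc(COc2ccnc(Nc3ccc(C#N)cc3)n2)cc1` gives 102000 nM and compound 2 `N#Cc1ccc(Nc2nccc(OCc3ccccc3C#N)n2)cc1` gives 113000 nM, which is a 1.1-fold higher number from compound 1 to compound 2 (0.04 log units; within the scatter). Compound 3 `N#Cc1ccc(Nc2nccc(OCc3cccc(C#N)c3)n2)cc1` has the lowest number of the three at 4100 nM, as shown by a 25-fold lower number from compound 1 to compound 3 (1.40 log units; beyond the scatter) and a 28-fold lower number from compound 2 to compound 3 (1.44 log units; beyond the scatter). Compound 4 `N#Cc1ccc(COc2ccnc(Nc3ccc(C#N)cc3)n2)cc1` differs from compound 3 by 4-cyanophenyl in place of 3-cyanophenyl on a saturated chain carbon bound to an oxygen on an aromatic ring, with 4-cyanophenyl in place of 3-cyanophenyl on a saturated chain carbon bound to an oxygen on an aromatic ring. Among the compounds with values here, no measured step covers this exact swap, but a 28-fold lower number from compound 2 to compound 3 (1.44 log units; beyond the scatter) shows that moving the nitrile can matter. A large rise is expected, which gives a 7.3-fold higher number from compound 3 to compound 4 (0.86 log units; beyond the scatter). For compound 4 the estimated value is 30000 nM, with an expected range of 5000 nM to 120000 nM.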

Compound 4, half-maximal cytotoxic concentration: 209000 nM
Compound 4: middle estimate off by 7.0-fold (0.84 log units), on the low side; measured number outside the range, above it.
By their numbers in this assay, from the lowest: compound 3; then compounds 1, 2 and 4 (each within the scatter of the next, the first and the last beyond it).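

The 4-cyanophenyl group does not share the low number of the 3-cyanophenyl group (a 51-fold higher number from compound 3 to compound 4 (1.71 log units; beyond the scatter)), so among the nitrile isomers the large drop in this assay belongs to the 3-cyanophenyl group alone. The 4-cyanophenyl and 2-cyanophenyl groups do not separate (a 1.8-fold higher number from compound 2 to compound 4 (0.27 log units; within the scatter)), and cyano in place of methoxy gives only a modest step (a 2.0-fold higher number from compound 1 to compound 4 (0.31 log units; beyond the scatter)).

From the compounds shown here alone, whether an amine or a carboxylic acid in the place of the nitrile of compound 3 would keep its low number stays open. No supporting data explain why compound 3 stands apart.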